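Cytotoxicity limits across the amide series

This account rests on a few compounds, and the source may have more. Where it says the series, first, only, none or still open, it means among the compounds named here.

Three members of the series have been run in an ADME assay on BJ cells (Homo sapiens) for cytotoxicity, read by CellTiter-Glo and resazurin assay, with a stated time of 72 h; on this read-out higher numbers stand for an effect only at larger amounts of compound and lower numbers for an effect already at smaller amounts. Compound 1 `CC(C)N(Cc1cccc(OCCCCCC(=O)O)c1)C(=O)c1ccc(-c2ccco2)cc1` returns only a limit of the assay, giving > 26000 nM in this assay. Compound 2 `CC(C)Oc1cccc(-c2ccc(C(=O)N(Cc3cccc(OCCCCCC(=O)O)c3)C(C)C)cc2)c1` likewise returns only a limit, > 26000 nM, in this assay. Compound 3 `CCOC(=O)CCCCCOc1cccc(CN(C(=O)c2ccc(-c3cccc(OC(C)C)c3)cc2)C(C)C)c1` too stands at a limit, > 26000 nM, in this assay. The core of compound 3 differs from that of compound 2 by ethyl in place of hydrogen on an oxygen next to a carbonyl group. Compound 1 differs from compound 2 by furan-2-yl in place of 3-isopropoxyphenyl on an aromatic carbon, and this change gives a step that the two limits leave unreadable from compound 2 to compound 1; its size cannot be read because all three values sit at the limit of > 26000 nM in this assay, at which 3 of the 3 values shown sit.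

Compound 4 `CCOC(=O)CCCCCOc1cccc(CN(C(=O)c2ccc(-c3ccco3)cc2)C(C)C)c1` has not yet been measured. It differs from compound 3 by furan-2-yl in place of 3-isopropoxyphenyl on an aromatic carbon, the same change as that between compound 2 and compound 1. Compound 4 is expected to show a step that the limit leaves unreadable from compound 3 to compound 4 in this assay. That expectation rests on compound 2 and compound 1 both standing at the limit of > 26000 nM in this assay, at which 3 of the 3 values shown sit. Compound 4 is accordingly estimated at 40000 nM, with a range from 20000 nM to 100000 nM, most likely again reported only as a limit.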

Compound 4, half-maximal effective concentration: > 26000 nM
Compound 4: only a limit was reported; the forecaster's own chance of this, stated with the estimate: 90%; the middle value is on the limit's open side.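

Compound 4 also returns only a limit of the assay, > 26000 nM. No step to compound 4 from compound 3 or compound 1 can be read, because every value shown stands at the same limit: the limit of > 26000 nM in this assay, at which 4 of the 4 values shown sit.

The compounds shown leave open at what concentration any of the four would show an effect, and whether the furan-2-yl or ethyl changes would shift it.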